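The compounds below may be only part of what the source reports. "The series", "measured", "known", "first", "only" and "open" are said of these compounds alone.

Measured compounds:
Compound 1, `O=C(Nc1ccc(Cl)c(-c2nnc3c(Cl)cccn23)c1)c1c(F)cccc1Cl`, gives 72300 nM in a functional assay on A549 cells (Homo sapiens) for antiproliferative activity, read by MTT assay, with a stated time of 72 h; a higher number here means a weaker inhibitor, a lower number a stronger inhibitor.
Compound 2, `O=C(Nc1ccc(Cl)c(-c2nnc3c(Cl)cccn23)c1)c1ccccc1Cl`, reaches only the assay limit, > 100000 nM.
Compound 3, `O=C(Nc1ccc(Cl)c(-c2nnc3c(Cl)cccn23)c1)c1ccc(Cl)cc1`, gives 73600 nM.

All three share one core and differ only in the aromatic ring attached to the carbonyl carbon. Compound 3 and compound 1 sit within the scatter of each other: a 1.0-fold higher number from compound 1 to compound 3 (0.01 log units; within the scatter). Compound 2 offers only a limit, (the limit of > 100000 nM in this assay, at which 1 of the 3 values shown sits), so the step of an at least 1.3-fold lower number from compound 2 to compound 3 (0.13 log units; that floor lies within the scatter) has a floor that also lies within the scatter. Nothing among these three separates the compounds beyond the usual spread.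

Compound 4, `Cc1cc(Cl)ccc1C(=O)Nc1ccc(Cl)c(-c2nnc3c(Cl)cccn23)c1`, carries one change from compound 3: methyl in place of hydrogen on an aromatic carbon. Among the measured compounds shown here, no measured step exchanges methyl for hydrogen, so the nearest guide is the pair of substituent shifts on the same ring, a 1.0-fold higher number from compound 1 to compound 3 (0.01 log units; within the scatter) and an at least 1.3-fold lower number from compound 2 to compound 3 (0.13 log units; that floor lies within the scatter), both small. The same quiet outcome is expected here, with no step beyond the scatter in either direction. The expected step is a 1.1-fold lower number from compound 3 to compound 4 (0.02 log units; within the scatter). Compound 4 is therefore estimated at 70000 nM, with a range of 30000 nM to 150000 nM.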

Compound 4, half-maximal inhibitory concentration: > 100000 nM
Compound 4: only a limit was reported (the forecaster's own chance of this, stated with the estimate: 30%); middle value at least 1.4-fold (0.15 log units) away from the limit.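

Compound 4 places a methyl group on the 4-chlorophenyl ring, ortho to a large group and meta to the chloro group, and in this assay compound 4 gives only a limit, > 100000 nM. The methyl gives an at least 1.3-fold higher number from compound 3 to compound 4 (0.13 log units; that floor lies within the scatter), and the full ring exchange gives an at least 1.3-fold higher number from compound 1 to compound 4 (0.14 log units; that floor lies within the scatter), so neither step shows a real loss of activity, although a larger true step remains possible. The step between the two compounds that both stand at the limit cannot be read, and such limits now make up much of this small set: the limit of > 100000 nM in this assay, at which 2 of the 4 values shown sit.

Still open, from the compounds shown here alone, is whether an amine, a methoxy group or a carboxylic acid at this same place would give a number within the range of the assay. Also open, going by these compounds, is whether any change to this ring can produce a step beyond the scatter.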